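A few compounds are considered here, and "the series" means these few. Any claim that something is new, unique, unknown or untested is made for them only; others in the source may bear on it.

Of the compounds shown here, three have so far been tested in an ADME assay on HepG2 cells (Homo sapiens) for cytotoxicity, read by CellTiter-Glo and resazurin assay, with a stated time of 72 h (a lower number here means that less compound is needed, a higher number that more compound is needed for the effect), and each of them reached only the limit of that assay. Compound 1 `CC(C)N(Cc1cccc(OCCCCCC(=O)O)c1)C(=O)c1ccc(-c2cccc3ccccc23)cc1` gives > 26000 nM in this assay, a limit rather than a number. Compound 2 `CC(C)Oc1cccc(-c2ccc(C(=O)N(Cc3cccc(OCCCCCC(=O)O)c3)C(C)C)cc2)c1` gives > 26000 nM, again a limit. Compound 3 `CCOC(=O)CCCCCOc1cccc(CN(C(=O)c2ccc(-c3cnc(OC)nc3OC)cc2)C(C)C)c1` gives > 26000 nM, also a limit. For the measured compounds named here, the one change with both ends measured, a step that the two limits leave unreadable from compound 1 to compound 2, has both ends at the limit, so its size is not readable. All three values therefore sit at the limit of > 26000 nM in this assay, at which 3 of the 3 values shown sit, and compound 3 stands there together with the other two.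

Compound 4 `CCOC(=O)CCCCCOc1cccc(CN(C(=O)c2ccc(-c3ccc4[nH]ccc4c3)cc2)C(C)C)c1` differs from compound 3 in one place: 1H-indol-5-yl in place of 2,4-dimethoxypyrimidin-5-yl on an aromatic carbon. Going by the values given here, no measured step bears on this change, since the only step between measured compounds is hidden by the two limits. Nothing in the measurements points to a step beyond the scatter in either direction. Compound 4 is therefore expected to report a limit as well, with a step that the limit leaves unreadable from compound 3 to compound 4 as the estimated step. The estimate for compound 4 in this assay is 40000 nM, with a range from 15000 nM to 100000 nM.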

Compound 4, half-maximal effective concentration: > 26000 nM
Compound 4: only a limit was reported; the forecaster's own chance of this, stated with the estimate: 85%; the middle value does not contradict the limit.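

Compound 4 gives only a limit, > 26000 nM and not a number, so no size can be read for the change from compound 3 to compound 4. The compounds shown leave open at what concentration any of them would reach the effect in this assay and whether swapping these groups alters it, with every value at the same point: the limit of > 26000 nM in this assay, at which 4 of the 4 values shown sit.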